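Estimating a Dimethoxyphenyl Analogue in a Cytotoxicity Series

A few compounds are considered here, and "the series" means these few. Any claim that something is new, unique, unknown or untested is made for them only; others in the source may bear on it.

Compound 2 `CCOc1ccc(Nc2nc(SCc3ccc(C(F)(F)F)cc3)nc3ccccc23)cc1` gives 33000 nM in a functional assay on HGC-27 cells (Homo sapiens) for cytotoxicity, read by MTT assay, with a stated time of 72 h (on this read-out lower numbers stand for stronger inhibition and higher numbers for weaker inhibition), the higher of the two numbers on record, yet compound 1 `O=[N+]([O-])c1ccc(Nc2nc(SCc3ccc(C(F)(F)F)cc3)nc3ccccc23)cc1`, which gives 16600 nM, sits within the scatter of it, as the step of a 2.0-fold higher number from compound 1 to compound 2 (0.30 log units; within the scatter) shows. Compound 3 `COc1ccc(Nc2nc(SCc3ccc(C(F)(F)F)cc3)nc3ccccc23)cc1OC` carries 3,4-dimethoxyphenyl in place of 4-ethoxyphenyl on a nitrogen on an aromatic ring. Within the data shown here, no measured step covers this exchange; the single step known, at the same nitrogen, stayed within the scatter. Compound 3 is therefore expected to show no step beyond the scatter, a 1.1-fold lower number from compound 2 to compound 3 (0.04 log units; within the scatter). Compound 3 is estimated at 30000 nM in this assay, between 10000 nM and 90000 nM.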

Compound 3, half-maximal inhibitory concentration: 17900 nM
Beside the measured number, compound 3's estimate is 1.7-fold (0.22 log units) above it, within the range that was stated.
By their numbers in this assay, from the lowest: compounds 1, 3 and 2 (each within the scatter of the next).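

In this assay, 3,4-dimethoxyphenyl in place of 4-ethoxyphenyl on the nitrogen gives a 1.8-fold lower number from compound 2 to compound 3 (0.27 log units; within the scatter), and the same group in place of 4-nitrophenyl gives a 1.1-fold higher number from compound 1 to compound 3 (0.03 log units; within the scatter). A ring with two oxygen substituents at this position therefore reads like both earlier rings, so compound 1, compound 2 and compound 3 all lie within the scatter of one another. Nothing available bears on why these numbers lie so close.

The compounds shown leave open whether an amine or a carboxylic acid on this ring would give a step beyond the scatter. They also leave open whether any exchange at this nitrogen can do so.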